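A few compounds are considered here, and "the series" means these few. Any claim that something is new, unique, unknown or untested is made for them only; others in the source may bear on it.

Of the compounds shown here, three built on one shared core have been measured in a functional assay on HeLa cells (Homo sapiens) for inhibition, read by MTT assay, with a stated time of 72 h; a higher number here means a weaker inhibitor, a lower number a stronger inhibitor. Compound 1 `CNC(=O)CCCCCCCn1nc(-c2cnc3[nH]ccc3c2)c2c(N)ncnc21`, whose chain ends in methylcarbamoyl, gives 29100 nM. Compound 2 `Nc1ncnc2c1c(-c1cnc3[nH]ccc3c1)nn2CCCCCCCCC(=O)NO`, whose chain ends in hydroxycarbamoyl, gives 7470 nM, and compound 3 `Nc1ncnc2c1c(-c1cnc3[nH]ccc3c1)nn2CCCCCCCCCC(=O)NO`, with the same ending on a longer chain, gives 7560 nM. Compound 2 thus sits at the low, stronger end of these numbers, level with compound 3 and not ahead of it.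

The next compound, compound 4 `Nc1nc2cc(-c3nn(CCCCCCCCC(=O)NO)c4ncnc(N)c34)ccc2o1`, keeps the chain of compound 2 and changes a different part of the molecule: a group of 10 heavy atoms (7 carbon, 2 nitrogen, 1 oxygen; one five-membered aromatic ring with 2 hetero atoms, one six-membered aromatic ring of carbon only) in place of a group of 9 heavy atoms (7 carbon, 2 nitrogen; one five-membered aromatic ring with 1 hetero atom, one six-membered aromatic ring with 1 hetero atom), on an aromatic carbon. The entering group, 2-amino-1,3-benzoxazol-5-yl, sits on an aromatic carbon of a five-membered aromatic ring with 2 nitrogen.

The measured steps offer little guidance here. a 3.9-fold lower number from compound 1 to compound 2 (0.59 log units; beyond the scatter) and a 3.8-fold lower number from compound 1 to compound 3 (0.59 log units; beyond the scatter) are modest, and a 1.0-fold higher number from compound 2 to compound 3 (0.01 log units; within the scatter) lies within the scatter, but all three concern the chain and none touches this group. The data therefore give no firm direction, and the modest size of those steps is only a rough yardstick. The expected step is a 1.5-fold lower number from compound 2 to compound 4 (0.17 log units; within the scatter), which would not go beyond the scatter, although the uncertainty is wide in both directions. In this assay, the estimated value for compound 4 is 5000 nM, with an expected range from 1200 nM to 20000 nM.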

Compound 4, half-maximal inhibitory concentration: 10200 nM
Estimate against measurement, compound 4: 2.0-fold (0.31 log units) below, within the range that was stated.
By their numbers in this assay, from the lowest: compounds 2, 3 and 4 (each within the scatter of the next); then compound 1.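

This is the first change shown away from the chain. In this assay, putting 2-amino-1,3-benzoxazol-5-yl on this aromatic carbon of the five-membered aromatic ring with 2 nitrogen gives a 1.4-fold higher number from compound 2 to compound 4 (0.14 log units; within the scatter) and so does not separate the two groups, even though the six-membered aromatic ring now holds carbon only and the entering group brings an oxygen. Nothing measured alongside these numbers accounts for this result.

The compounds shown leave open what other groups would do on this carbon, such as a plain phenyl ring or a simple amine, so two groups that read alike say little about how the position treats groups in general. On these data alone, it also remains open whether 2-amino-1,3-benzoxazol-5-yl would behave the same with a methylcarbamoyl ending or a longer chain, and thus whether the difference between the chain endings seen in a 3.9-fold lower number from compound 1 to compound 2 (0.59 log units; beyond the scatter) carries over to this group.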